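Notes on the shared core: from compound 3 to compound 4

This account rests on a few compounds, and the source may have more. Where it says the series, first, only, none or still open, it means among the compounds named here.

Values in a functional assay on MGC-803 cells (Homo sapiens) for cytotoxicity, read by MTT assay, with a stated time of 72 h; on this read-out lower numbers stand for stronger inhibition and higher numbers for weaker inhibition:
compound 1, `COc1ccc(Nc2cc(C)nc(SCc3nc4ccccc4[nH]3)n2)cc1`: 51100 nM
compound 2, `Cc1cc(Nc2ccc(Cl)cc2)nc(SCc2nc3ccccc3[nH]2)n1`: 28200 nM
compound 3, `Cc1cc(N2CCCCC2)nc(SCc2nc3ccccc3[nH]2)n1`: > 100000 nM

For compound 3 the value in this assay is a limit, not a number. Compound 4, `Cc1cc(NCCO)nc(SCc2nc3ccccc3[nH]2)n1`, differs from compound 3 by (2-hydroxyethyl)amino in place of piperidin-1-yl on an aromatic carbon. Among the measured compounds shown here, the steps that bear on this are those that introduced the piperidin-1-yl group: an at least 1.9-fold higher number from compound 1 to compound 3 (0.29 log units; that floor lies within the scatter) and an at least 3.5-fold higher number from compound 2 to compound 3 (0.54 log units; beyond the scatter). Both went toward weaker inhibition, only one beyond the scatter, and compound 3 sits at the limit of > 100000 nM in this assay, at which 1 of the 3 values shown sits. Returning to an amino substituent, here with a short chain rather than an aryl group, is expected to move compound 4 back toward the numbers of compound 1 and compound 2, but the size is uncertain; the expected step is an at least 1.4-fold lower number from compound 3 to compound 4 (0.15 log units; that floor lies within the scatter). For compound 4 the estimated value is 70000 nM, within 25000 nM to 200000 nM.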

Compound 4, half-maximal inhibitory concentration: > 100000 nM
Compound 4: a limit, no number; the forecaster's own chance of this, stated with the estimate: 40%; middle value at least 1.4-fold (0.15 log units) away from the limit.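

In this assay compound 4 ends at a limit, not a number, as compound 3 does: the limit of > 100000 nM in this assay, at which 2 of the 4 values shown sit.

The step between these two cannot be read, so piperidin-1-yl and (2-hydroxyethyl)amino are not separated at this position. With 2-hydroxyethyl on the nitrogen there is an at least 3.5-fold higher number from compound 2 to compound 4 (0.54 log units; beyond the scatter), and an at least 1.9-fold higher number from compound 1 to compound 4 (0.29 log units; that floor lies within the scatter), so a nitrogen carrying a short chain here does not restore the numbers of the aryl compounds.

Still open, from the compounds shown here alone, is whether an aromatic ring on that nitrogen is what gives a measurable value. A benzylamino group or a longer chain ending in a dimethylamino group would test this.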